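The source may hold more compounds than are shown below. What is called first, only, known or untested is meant among the compounds shown, and "the series" means these compounds.

Measured in a functional assay on MCF7 cells (Homo sapiens) for antiproliferative activity, read by MTT assay, with a stated time of 72 h; a lower number here means a stronger inhibitor, a higher number a weaker inhibitor:
- compound 1 `CC(C)(C)c1ccc(/C=C/C(=O)c2ccc(OCC(=O)N[C@H]3CCOC3=O)cc2)cc1`: 16400 nM
- compound 2 `CCCCCCCCCCSC(=S)N[C@H]1CCOC1=O`: > 64000 nM (a limit of the assay)

In this assay, among the compounds with values here, compound 1 gives 16400 nM, and this is the only actual number available so far. Compound 2 gives > 64000 nM, which is a limit and not a number. The next compound to be tested is compound 3 `O=C(COc1ccc(C(=O)/C=C/c2ccccc2Br)cc1)N[C@H]1CCOC1=O`. It keeps the rest of compound 1 and differs in one place: 2-bromophenyl in place of 4-(tert-butyl)phenyl on a double-bonded chain carbon bound to a double-bonded chain carbon. It has 2-bromophenyl in place of 4-(tert-butyl)phenyl on a double-bonded chain carbon bound to a double-bonded chain carbon. Within the data shown here, no measured pair shows what such a swap does, so no step beyond the scatter is expected in this assay, in either direction. The expected change is a 1.2-fold higher number from compound 1 to compound 3 (0.09 log units; within the scatter). For compound 3 the estimated value is 20000 nM, with an expected range of 8000 nM to 50000 nM.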

Compound 3, half-maximal inhibitory concentration: 15300 nM
Compound 3: middle estimate off by 1.3-fold (0.12 log units), on the high side, and the stated range covers the measured number.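

In this assay, this position gives its first measured step: putting 2-bromophenyl in place of 4-(tert-butyl)phenyl on a double-bonded chain carbon bound to a double-bonded chain carbon gives a 1.1-fold lower number from compound 1 to compound 3 (0.03 log units; within the scatter). The step lies within the scatter, so this exchange of one aromatic ring for another, with 10 heavy atoms leaving and 7 entering, does not separate compound 1 from compound 3 in this assay. Nothing shown gives a cause for this result.

The compounds shown leave open whether a phenyl ring carrying an amine or a carboxylic acid at this place, or an unsubstituted phenyl, would move the number beyond the scatter. They also leave open whether the place of the substituent on the ring matters, as 4-bromophenyl is not among them.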